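Shortening the Chain of Compound 3: What to Expect

The source may report more compounds than this note shows. Statements on the series, on what has been measured and on what is new or still open speak of the compounds shown alone.

Three measured compounds share one core. In an assay on isolated protein for inhibition of tissue alpha-L-fucosidase (Bos taurus), tested at 1000 uM (a lower number here means less inhibition, a higher number more inhibition at the concentration tested (going by the name of the read-out)), compound 1 `OC[C@@]1(c2ccc(F)cc2)NC[C@@H](O)[C@@H]1O` gives 0%, and compound 2 `Cc1ccc([C@]2(CO)NC[C@@H](O)[C@@H]2O)cc1` gives 0%; the step of no change at the digits printed from compound 1 to compound 2 (within the scatter) is flat. Compound 3 `CCCCCCCCC[C@]1(CO)NC[C@@H](O)[C@@H]1O` likewise gives 0%, level with compounds 1 and 2 at the digits shown. Compound 4 `CCCC[C@]1(CO)NC[C@@H](O)[C@@H]1O` differs from compound 3 by hydrogen in place of pentyl on a saturated chain carbon, four bonds along the chain from a saturated ring carbon. Among the compounds with values here, no measured step touches this chain, and the only step at hand, from compound 1 to compound 2, stayed within the scatter while every value shown sits at the floor of the read-out. Compound 4 is therefore expected to give 0%, between 0% and 10%. The expected step of no change at the digits printed from compound 3 to compound 4 (within the scatter) thus lies within the scatter, with no direction beyond it.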

Compound 4, a percentage reported as inhibition, at one concentration (the size of the read-out at that concentration, not a potency): 20.8%
Compound 4: middle estimate off by 20.8 percentage points, on the low side, outside the stated range (above it).
By their numbers in this assay, from the lowest: compounds 1, 2 and 3 (each within the scatter of the next); then compound 4.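

In this assay, this chain position is the first place among the compounds shown where a change lifts the read-out off the floor: hydrogen in place of pentyl gives a number 20.8 percentage points higher from compound 3 to compound 4 (beyond the scatter). The earlier step, methyl in place of fluoro on an aromatic carbon, had moved nothing at the digits printed. Nothing at hand accounts for the rise.

With a single step along this chain, no trend with chain length can be drawn. As far as these compounds go, whether a shorter chain, or an amine or a carboxylic acid at the chain end, would change the inhibition stays open.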